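This account rests on a few compounds, and the source may have more. Where it says the series, first, only, none or still open, it means among the compounds named here.

Measured compounds:
compound 1, `Oc1cccc(-c2cc(-c3cccs3)cc(-c3ccccc3O)n2)c1`
compound 2, `Oc1cccc(-c2cc(-c3ccco3)cc(-c3ccccc3O)n2)c1`
compound 3, `Oc1ccccc1-c1cc(-c2ccccn2)cc(-c2ccccc2O)n1`

In a functional assay on HeLa cells (Homo sapiens) for cytotoxicity, read by CCK-8 assay (on this read-out higher numbers stand for weaker inhibition and lower numbers for stronger inhibition), compound 1 gives only a limit of the assay, > 50000 nM. Compound 2 also gives only a limit in this assay, > 50000 nM. Compound 3 likewise gives only a limit in this assay, > 50000 nM. Compound 3 therefore stands at the same limit as the other two, and no number places it above or below them.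

For the measured compounds named here, the one step measured between neighbours, from compound 1 to compound 2, is a step that the two limits leave unreadable from compound 1 to compound 2; the limit of > 50000 nM in this assay, at which 3 of the 3 values shown sit, covers every value shown, so nothing about size or direction can be read from it.

Compound 4, `Oc1cccc(-c2cc(-c3ccccn3)cc(-c3ccccc3O)n2)c1`, differs from compound 3 in a single place: 3-hydroxyphenyl in place of 2-hydroxyphenyl on an aromatic carbon. Going by the values given here, no measured step touches this change, and the only step that exists is unreadable, so the expectation rests on the limit at which compound 3 sits. With compound 3 at > 50000 nM, compound 4 is expected to remain at that limit as well. The expected step from compound 3 to compound 4 in this assay is a number no higher from compound 3 to compound 4 (the limit leaves the size open). Compound 4 is estimated at 50000 nM, within a range from 20000 nM to 100000 nM.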

Compound 4, half-maximal inhibitory concentration: 2020 nM
Estimate against measurement, compound 4: 25-fold (1.39 log units) above; the measured number lies below the stated range.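

The position next to the ring nitrogen turns out not to be indifferent in this assay: 3-hydroxyphenyl in place of 2-hydroxyphenyl, with the same atoms joined differently, gives an at least 24-fold lower number from compound 3 to compound 4 (1.39 log units; beyond the scatter). The pyridin-2-yl group matters as well when 3-hydroxyphenyl is kept, with its replacement of furan-2-yl giving an at least 24-fold lower number from compound 2 to compound 4 (1.39 log units; beyond the scatter) and its replacement of thiophen-2-yl giving an at least 24-fold lower number from compound 1 to compound 4 (1.39 log units; beyond the scatter). Among these compounds, neither 3-hydroxyphenyl alone, as in compound 1 and compound 2, nor pyridin-2-yl alone, as in compound 3, moves the read-out off the limit, and only compound 4, which carries both, gives a number: the limit of > 50000 nM in this assay, at which 3 of the 4 values shown sit.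

The compounds shown leave open how far compound 1, compound 2 and compound 3 really lie from compound 4, as each step gives only a minimum size. They also leave open whether the hydroxyl of the 3-hydroxyphenyl group could give way to a methoxy group or an amine, and whether pyridin-3-yl or a plain phenyl ring could take the place of pyridin-2-yl.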